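The compounds below may be only part of what the source reports. "The series", "measured", "known", "first", "only" and "open" are said of these compounds alone.

Measured in an ADME assay on L02 cells (Homo sapiens) for cytotoxicity, read by MTT assay, with a stated time of 48 h; on this read-out higher numbers stand for weaker inhibition and lower numbers for stronger inhibition:
Compound 1, `COc1cc2ccc(=O)oc2cc1OCCOc1no[n+]([O-])c1S(=O)(=O)c1ccccc1`: 10900 nM
Compound 2, `COc1cc2ccc(=O)oc2cc1OCCCCOc1no[n+]([O-])c1S(=O)(=O)c1ccccc1`: 9330 nM

Compound 1 stands at the top of these two numbers, but compound 2 lies within the usual scatter of repeated measurements of it, so the two cannot be told apart on this evidence, and no direction of change can be read from them.

Compound 3, `COc1cc2cc(N)c(=O)oc2cc1OCCOc1no[n+]([O-])c1S(=O)(=O)c1ccccc1`, has not yet been measured. It derives from compound 1 by a single change: amino in place of hydrogen on an aromatic carbon. For the measured compounds named here, no measured pair shows the effect of such a change, so the expectation can rest only on the fact that the one variation seen so far, between compound 1 and compound 2, left the number essentially where it was. In this assay a step of modest size at most is expected, in either direction, and most likely none beyond the scatter. For compound 3 the expected step is a 1.1-fold lower number from compound 1 to compound 3 (0.04 log units; within the scatter). Compound 3 is therefore estimated at 10000 nM, with a range from 3000 nM to 32000 nM.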

Compound 3, half-maximal inhibitory concentration: 9820 nM
Compound 3: middle estimate off by 1.0-fold (0.01 log units), on the high side; low and high end bracket the measured number.
By their numbers in this assay, from the lowest: compounds 2, 3 and 1 (each within the scatter of the next).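

In this assay, putting amino in place of hydrogen on an aromatic carbon, two atoms from the ring oxygen, gives a 1.1-fold lower number from compound 1 to compound 3 (0.05 log units; within the scatter) and so leaves compound 1 and compound 3 indistinguishable. For the compounds shown here, the earlier pair varied only the connecting chain of the molecule, so this is the first look at a change on the six-membered aromatic ring with 1 oxygen, and here the added nitrogen, with its hydrogen-bond donor and acceptor, brings no readable difference in this cell toxicity measure. The result holds for this one group at this one position, and nothing measured here explains why the two numbers sit so close.

Still open, going by these compounds, is whether a different group at the same position, such as a methyl, a hydroxyl, a carboxylic acid or a larger phenyl ring, would also leave the number within the scatter or would move it clearly. Also open, on these data alone, is whether amino would behave the same way on the longer chain of compound 2, or on another carbon of the same ring.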